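This account rests on a few compounds, and the source may have more. Where it says the series, first, only, none or still open, it means among the compounds named here.

Values in a functional assay on MCF7 cells (Homo sapiens) for cytotoxicity, read by ELISA, with a stated time of 4 days; on this read-out higher numbers stand for weaker inhibition and lower numbers for stronger inhibition:
- compound 1 `Cc1ccsc1-c1cc(-c2ccoc2)cc(-c2ccco2)n1`: 18300 nM
- compound 2 `Cc1ccsc1-c1cc(-c2ccoc2)cc(-c2ccc(Cl)cc2)n1`: 20300 nM
- compound 3 `Clc1ccc(-c2cc(-c3ccoc3)cc(-c3ccco3)n2)s1`: not yet measured

For the measured compounds named here, compound 1 and compound 2 lie within the scatter of each other, so compound 1 has no separation from the only other number available.

The change under consideration is 5-chlorothiophen-2-yl in place of 3-methylthiophen-2-yl on an aromatic carbon. In words, 5-chlorothiophen-2-yl replaces 3-methylthiophen-2-yl next to the ring nitrogen, keeping the rest of the core of compound 1.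

Going by the values given here, only one measured step is available, a 1.1-fold higher number from compound 1 to compound 2 (0.05 log units; within the scatter). It lies within the scatter, but it concerns the furan-2-yl group and not the place changed here, so it bears on the new change only indirectly. Among the compounds with values here, no measured compound varies the 3-methylthiophen-2-yl group, and the data therefore give no direct size for this change.

Within the data shown here, with that single flat step as the only guide, no step beyond the scatter is expected in this assay, and the range is kept wide. The expected outcome is a 1.1-fold lower number from compound 1 to compound 3 (0.06 log units; within the scatter). For compound 3 the estimated value is 16000 nM, with an expected range from 6000 nM to 40000 nM.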

Compound 3, half-maximal inhibitory concentration: 4740 nM
The estimate for compound 3 lay 3.4-fold (0.53 log units) above the measured number, and the stated range ends above it.
By their numbers in this assay, from the lowest: compound 3; then compounds 1 and 2 (each within the scatter of the next).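

In this assay, for the compounds shown here, the place next to the ring nitrogen responds to substitution: 5-chlorothiophen-2-yl in place of 3-methylthiophen-2-yl gives a 3.9-fold lower number from compound 1 to compound 3 (0.59 log units; beyond the scatter), whereas the only earlier step, at the furan-2-yl group, was a 1.1-fold higher number from compound 1 to compound 2 (0.05 log units; within the scatter). The entering and leaving groups have the same heavy-atom count and the same ring type, so the shift arises without a change in those counted features, although the swap removes the methyl and introduces the chlorine in a single step, and the two contributions cannot be separated here. No measured evidence accounts for this shift.

Going by these compounds, it remains open whether the lower number follows from the chlorine, from the loss of the methyl, or from the place of either on the thiophene ring, which plain thiophen-2-yl, 5-methylthiophen-2-yl and 3-chlorothiophen-2-yl groups at this place would help to separate. Also open, on these data alone, are whether the shift carries over to the core of compound 2, with its 4-chlorophenyl group, and how a 5-bromothiophen-2-yl group or a carboxylic acid on the thiophene ring would read out.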